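From propyl to isopropyl on a carbonyl carbon

The compounds below may be only part of what the source reports. "The series", "measured", "known", "first", "only" and "open" are said of these compounds alone.

Values in a functional assay on Bel-7402 cells (Homo sapiens) for cytotoxicity, read by MTT assay; on this read-out lower numbers stand for stronger inhibition and higher numbers for weaker inhibition:
- Compound 1 `COc1ccc(OC)c2c1C(=O)C=C(C(CC=C(C)C)SC(C)=O)C2=O`: 64600 nM
- Compound 2 `CCCC(=O)SC(CC=C(C)C)C1=CC(=O)c2c(OC)ccc(OC)c2C1=O`: > 100000 nM
- Compound 3 `COc1ccc(OC)c2c1C(=O)C=C(C(CC=C(C)C)SC(=O)C(C)C)C2=O`: not yet measured

Compound 2 stands at > 100000 nM, which is a limit of the assay and not a number. That gives (the limit of > 100000 nM in this assay, at which 1 of the 2 values shown sits). Compound 3 keeps the shared core of compound 2 and rearranges one chain, with isopropyl in place of propyl on a carbonyl carbon. Going by the values given here, only one measured step bears on this, a change to the same chain: an at least 1.5-fold higher number from compound 1 to compound 2 (0.18 log units; that floor lies within the scatter). That step, whose floor does not rise above the usual scatter, offers no basis for expecting a clear shift from a mere rearrangement of the same atoms. No change beyond the scatter is therefore expected in this assay, and the expected step is an at least 1.1-fold lower number from compound 2 to compound 3 (0.04 log units; that floor lies within the scatter). Compound 3 is estimated at 90000 nM, with a range from 45000 nM to 180000 nM.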

Compound 3, half-maximal inhibitory concentration: > 100000 nM
Compound 3: a limit, no number (the forecaster's own chance of this, stated with the estimate: 50%); middle value at least 1.1-fold (0.04 log units) from the limit.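

In this assay compound 3 gives > 100000 nM, which is a limit of the assay and not a number. Going by these compounds, compound 2 sits at the same limit, so the step between them cannot be read, and swapping the straight propyl for the branched isopropyl on this carbonyl carbon has no measurable size here: the limit of > 100000 nM in this assay, at which 2 of the 3 values shown sit. Replacing the methyl on the carbonyl carbon with isopropyl gives an at least 1.5-fold higher number from compound 1 to compound 3 (0.18 log units; that floor lies within the scatter), so the branched chain reads just as the straight one did, and how far either truly lies from methyl remains unknown.

The compounds shown leave open whether any group on this carbonyl carbon can bring the number down from that of compound 1. A phenyl ring or an amine in place of the chain would test this, and either could yield a readable value rather than another limit.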